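A few compounds are considered here, and "the series" means these few. Any claim that something is new, unique, unknown or untested is made for them only; others in the source may bear on it.

Of the compounds shown here, three that share one core have been measured in a functional assay on HT-29 cells (Homo sapiens) for inhibition, read by WST assay, with a stated time of 48 h; a lower number here means a stronger inhibitor, a higher number a weaker inhibitor. Within the data shown here, compound 3 `COc1ccc(C(=O)CSc2nc3ccccc3[nH]2)cc1` gives 25200 nM and stands lowest of the two numbers known. Compound 2 `O=C(CSc1nc2ccccc2[nH]1)c1ccc(F)cc1` gives 78700 nM, and the change from fluoro to methoxy brings a 3.1-fold lower number from compound 2 to compound 3 (0.49 log units; beyond the scatter). Compound 1 `CCOc1ccc(C(=O)CSc2nc3ccccc3[nH]2)cc1` gives > 100000 nM, which is a limit of this assay and not a number. Trimming its ethoxy to methoxy brings an at least 3.9-fold lower number from compound 1 to compound 3 (0.59 log units; beyond the scatter), while swapping ethoxy for fluoro brings an at least 1.2-fold lower number from compound 1 to compound 2 (0.10 log units; that floor lies within the scatter).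

Compound 4 `O=C(CSc1nc2ccccc2[nH]1)c1ccccc1` has not yet been measured in this assay. It differs from compound 3 by hydrogen in place of methoxy on an aromatic carbon. Among the measured compounds shown here, two measured steps bear on this. Shortening the alkoxy group, an at least 3.9-fold lower number from compound 1 to compound 3 (0.59 log units; beyond the scatter), lowered the number, so a smaller group helped there. Yet compound 2, carrying a small fluoro instead of methoxy, gave a higher number than compound 3. The evidence therefore points both ways, and removing the methoxy entirely is a further step than either. A modest rise in the number is expected, a 2.0-fold higher number from compound 3 to compound 4 (0.30 log units; within the scatter), near the edge of the scatter. Compound 4 is estimated at 50000 nM, with a likely range from 15000 nM to 150000 nM.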

Compound 4, half-maximal inhibitory concentration: 38500 nM
Compound 4: middle estimate off by 1.3-fold (0.11 log units), on the high side; measured number inside the range.
By their numbers in this assay, from the lowest: compounds 3 and 4 (each within the scatter of the next); then compound 2. At a limit, above all of these: compound 1.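

Removing the methoxy from its place para to a large group leaves the reading in this assay almost untouched, with a 1.5-fold higher number from compound 3 to compound 4 (0.18 log units; within the scatter), so this oxygen-bearing group is not needed for the activity seen with compound 3. The bare ring also separates from the other two groups, with a 2.0-fold lower number from compound 2 to compound 4 (0.31 log units; beyond the scatter) and an at least 2.5-fold lower number from compound 1 to compound 4 (0.41 log units; beyond the scatter), which shows that fluoro and ethoxy each go with a higher number than hydrogen, while methoxy, the exception to this pattern, does not. The last of these steps is only a floor, because compound 1 stands at a limit of the assay and not at a number: the limit of > 100000 nM in this assay, at which 1 of the 4 values shown sits.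

The compounds shown carry only hydrogen, fluoro, methoxy or ethoxy at this place, so it remains open how an amine, a carboxylic acid or a longer alkoxy chain would read there. As far as these compounds go, it also remains open why methoxy stays level with hydrogen while fluoro does not, and whether any group at this place can bring the number well below those seen so far.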